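A few compounds are considered here, and "the series" means these few. Any claim that something is new, unique, unknown or untested is made for them only; others in the source may bear on it.

Of the compounds shown here, three that share one core have been tested in a functional assay on HCT-15 cells (Homo sapiens) for cytotoxicity, in the presence of a further agent that is not named here; a lower number here means a stronger inhibitor, a higher number a weaker inhibitor. Compound 1 `Clc1ccc(-c2cc(-c3ccsc3)nc(-c3ccco3)c2)o1` returns only the limit of the assay, > 50000 nM. Compound 2 `Clc1ccc(-c2cc(-c3ccc(Cl)o3)cc(-c3ccsc3)n2)cc1` gives a number in this assay, 5190 nM. Compound 3 `Clc1ccc(-c2cc(-c3cccnc3)nc(-c3ccsc3)c2)o1` again reaches only the assay limit, > 50000 nM. The steps between them read as follows: an at least 9.6-fold lower number from compound 1 to compound 2 (0.98 log units; beyond the scatter), an at least 9.6-fold higher number from compound 2 to compound 3 (0.98 log units; beyond the scatter), and a step that the two limits leave unreadable from compound 1 to compound 3. Compound 3 therefore stands, together with compound 1, at the limit of > 50000 nM in this assay, at which 2 of the 3 values shown sit, and only compound 2 sits inside the measurable range.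

Compound 4 `Clc1ccc(-c2cc(-c3ccsc3)nc(-c3ccccn3)c2)o1` differs from compound 3 in one place: pyridin-2-yl in place of pyridin-3-yl on an aromatic carbon. Within the data shown here, none of the measured steps exchanges one pyridyl for another; the steps that touch this position swap a furan-2-yl, a 4-chlorophenyl and a pyridin-3-yl, and of these only the 4-chlorophenyl of compound 2 yields a number. For compound 4 the change is expected to leave the number close to the limit, a number no higher from compound 3 to compound 4 (the limit leaves the size open), so compound 4 is estimated at 50000 nM with a range from 15000 nM to 150000 nM.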

Compound 4, half-maximal inhibitory concentration: > 50000 nM
Compound 4 gave a limit, no number; the forecaster's own chance of this, stated with the estimate: 70%; the middle value sits exactly at the limit.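

In this assay compound 4 also returns only a limit, so the pyridin-2-yl group, with the same atoms as pyridin-3-yl joined differently, yields no number at this position: the limit of > 50000 nM in this assay, at which 3 of the 4 values shown sit. Placing pyridin-2-yl where the 4-chlorophenyl stood gives an at least 9.6-fold higher number from compound 2 to compound 4 (0.98 log units; beyond the scatter), and the 4-chlorophenyl remains the only group at this position with a measurable value. The steps among compound 1, compound 3 and compound 4 cannot be read, as each joins two limits, so furan-2-yl, pyridin-3-yl and pyridin-2-yl cannot be ranked.

The compounds shown leave open whether the value of compound 2 depends on the chlorine or on the phenyl ring itself. A plain phenyl or a 4-methoxyphenyl at this position would separate the two.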